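This account rests on a few compounds, and the source may have more. Where it says the series, first, only, none or still open, it means among the compounds named here.

Measured compounds:
- compound 1 `COc1ccc(F)cc1N1C(=O)CSC1c1cccc(C(=O)NCCCCc2ccccc2)c1`: 2300 mL.min-1.g-1
- compound 2 `O=C(NCCCCn1cccn1)c1cccc(C2SCC(=O)N2c2cc(F)ccn2)c1`: 1200 mL.min-1.g-1

Notes on the series. In an ADME assay on microsomes from liver (Rattus norvegicus) for metabolic stability, read by LC-MS, using NADPH, with a stated time of 10 min, tested at 0.1 uM (on this read-out higher numbers stand for fast clearance and lower numbers for slow clearance), compound 1 gives 2300 mL.min-1.g-1. Compound 2 gives 1200 mL.min-1.g-1 in this assay. Compound 1 carries the larger of the two numbers, but the two values lie within the usual scatter of each other, so no ordering of compound 1 against compound 2 can be read from them. Among the compounds with values here, no step between measured compounds that differ in a single place is available in this assay, so nothing is known here about how a single change moves the read-out.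

Compound 3 `O=C(NCCCCc1ccccc1)c1cccc(C2SCC(=O)N2c2ccc(C3CC3)cc2)c1` has not yet been measured. It differs from compound 1 as follows: 4-cyclopropylphenyl in place of 5-fluoro-2-methoxyphenyl on an amide-type nitrogen in a ring. Within the data shown here, with no measured step of this kind to draw on, and both measured compounds sitting close together at the fast end, no move beyond the scatter is expected in this assay; the estimated step of no change at the digits printed from compound 1 to compound 3 (within the scatter) from compound 1 to compound 3 is therefore set near zero. Compound 3 is expected to give about 2300 mL.min-1.g-1 in this assay, with a range from 1000 mL.min-1.g-1 to 5000 mL.min-1.g-1.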

Compound 3, intrinsic clearance in microsomes: 2280 mL.min-1.g-1
Beside the measured number, compound 3's estimate is 1.0-fold (0.00 log units) above it; measured number inside the range.
By their numbers in this assay, from the lowest: compounds 2, 3 and 1 (each within the scatter of the next).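

Within the data shown here, this is the first single-place step: on an amide-type nitrogen in a ring, 4-cyclopropylphenyl in place of 5-fluoro-2-methoxyphenyl gives, in this assay, a 1.0-fold lower number from compound 1 to compound 3 (0.00 log units; within the scatter). The exchange removes the oxygen, the fluorine and the hydrogen-bond acceptor of the leaving group and brings in an all-carbon group with a three-membered ring, and this read-out does not separate the two groups on the core of compound 1. Nothing available explains this result.

The compounds shown leave open whether a group of a different kind at this position, such as an amine or a carboxylic acid in place of 4-cyclopropylphenyl, would give a step beyond the scatter. They also leave open whether a longer chain on the 4-position of the phenyl ring would do so, and whether the same exchange would read alike on a core other than that of compound 1.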